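The compounds below may be only part of what the source reports. "The series", "measured", "known", "first", "only" and "open" are said of these compounds alone.

Measured in an assay on isolated protein for inhibition of Ephrin type-B receptor 4 (Homo sapiens), read by HTRF, tested at 10 uM; a lower number here means less inhibition, a higher number more inhibition at the concentration tested (going by the name of the read-out):

Compound 1 `Cc1cccc(Oc2ccnc(N3CCC[C@H]3C(=O)NCc3cccnc3)n2)c1`: 0%
Compound 2 `CN(CCCn1ccnc1)C(=O)[C@@H]1CCCN1c1nccc(Nc2ccccc2)n1`: 0%
Compound 3 `Cc1cccc(N(C)c2cc(Nc3cccc(C(=O)N4CCCC5CCCCC54)c3)ncn2)c1`: 0%

Of the compounds shown here, three of rather different build have been tested, and none of them shows any inhibition in this assay. Compound 3 stands level with compound 1 and compound 2 at the digits shown. Its nearest neighbour on the numbers is compound 1, with no change at the digits shown, and its furthest is compound 2, again with no change at the digits shown; both gaps sit within the scatter. Among the compounds with values here, no pair of measured compounds differs in only one place, so no single-point step can be read from the data themselves.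

Compound 4 `Cc1cccc(N(C)c2cc(Nc3cccc(C(=O)N(CC(C)C)CC(C)C)c3)ncn2)c1` is the next member. Relative to compound 3 the change is confined to one spot: a group of 9 heavy atoms (8 carbon, 1 nitrogen; no ring) in place of a group of 10 heavy atoms (9 carbon, 1 nitrogen; one six-membered non-aromatic ring of carbon only, one six-membered non-aromatic ring with 1 hetero atom), on a carbonyl carbon

The core of compound 3 and the rest of its substituents are carried over unchanged. Since compound 3 sits at the floor of the read-out and the two other measured compounds do as well, the step from compound 3 to compound 4 is expected to be none beyond the scatter, namely no change at the digits printed from compound 3 to compound 4 (within the scatter). Compound 4 is therefore expected to give 0% in this assay, within a range of -8% to 10%.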

Compound 4, a percentage reported as inhibition, at one concentration (the size of the read-out at that concentration, not a potency): 0%
Compound 4: the middle estimate sits on the measured number at the digits printed, within the range that was stated.
By their numbers in this assay, from the lowest: compounds 1, 2, 3 and 4 (each within the scatter of the next).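

In this assay, putting diisobutylamino on the carbonyl carbon in place of the group with its two six-membered rings gives no change at the digits printed from compound 3 to compound 4 (within the scatter). Within the data shown here, this is the first step that changes a single place, and it shows that a group with no ring at this position reads the same as the two-ring group, with compound 4 at 0%. Nothing measured on these compounds bears on this result.

Since both ends of the step lie at the bottom of the read-out, it cannot tell whether this position has any influence on inhibition at the concentration tested, as a change here could only show up from a compound with a value above that level. Going by these compounds, it remains open whether a morpholine ring or a methylamino group on the same carbonyl carbon would give any inhibition in this assay, and whether a change elsewhere on the shared core would do so.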